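The compounds below may be only part of what the source reports. "The series", "measured", "known", "first", "only" and "open" are said of these compounds alone.

Measured compounds:
- compound 1 `CC(=O)CC[C@]1(C(C)=O)C(=O)O[C@@H](OC(C)=O)[C@H]1C` gives 7000 nM in a functional assay on B16 cells (Mus musculus) for cytotoxicity, read by MTT assay; on this read-out lower numbers stand for stronger inhibition and higher numbers for weaker inhibition
- compound 2 `CC(=O)O[C@@H]1OC(=O)[C@](C)(C(=O)CBr)[C@@H]1C` gives 6000 nM in this assay
- compound 3 `CC(=O)O[C@@H]1OC(=O)[C@@](Cc2ccccc2)(C(C)=O)[C@@H]1C` gives 45000 nM in this assay

Compound 1 stands second highest of the three numbers. Its nearest neighbour is compound 2, whose number lies within the scatter of compound 1, so no order between the two can be read. Compound 3 lies furthest away, with a number beyond the scatter higher than that of compound 1.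

Compound 4 `CC(=O)O[C@@H]1OC(=O)[C@@H](C(C)=O)[C@@H]1C` has not yet been measured. It differs from compound 1 in one place: hydrogen in place of 2-acetylethyl on a saturated ring carbon. Among the compounds with values here, no step between measured compounds isolates this change, so its size has to be guessed. Within the data shown here, the only hint comes from compound 3, where a different, larger group on the same ring carbon goes with a markedly higher number; compound 2 carries a methyl there and gives a number close to compound 1. Taken together the data give no firm direction, and a step of no more than the scatter is expected.

The step from compound 1 to compound 4 in this assay is therefore expected to be a 1.4-fold higher number from compound 1 to compound 4 (0.15 log units; within the scatter). For compound 4 the estimate is 10000 nM, with a range from 3500 nM to 30000 nM.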

Compound 4, half-maximal inhibitory concentration: > 50000 nM
Compound 4: only a limit was reported (the forecaster's own chance of this, stated with the estimate: 10%); at least 5.0-fold (0.69 log units) between middle value and limit.
By their numbers in this assay, from the lowest: compounds 2 and 1 (each within the scatter of the next); then compound 3. At a limit, above all of these: compound 4.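

In this assay compound 4 stands at a limit, > 50000 nM, and this is a limit of the assay, not a number. Hydrogen in place of 2-acetylethyl on the saturated ring carbon gives an at least 7.1-fold higher number from compound 1 to compound 4 (0.85 log units; beyond the scatter), the first step in the series that isolates a change at this position, and it shows that the 2-acetylethyl group of compound 1 cannot be removed from this ring carbon without loss of measurable inhibition in this assay. The true size of the step stays unknown, and only its lower bound can be stated: the limit of > 50000 nM in this assay, at which 1 of the 4 values shown sits.

The compounds shown leave open whether the ketone carbonyl of the 2-acetylethyl group matters or whether any carbon chain on this ring carbon would serve, and a plain butyl chain, a longer chain, or a chain ending in a carboxylic acid or an amine would separate these cases. Within the data shown here, also open is whether the acetoxy group and the acetyl group of the shared core contribute to the number of compound 1, since no step isolates a change at either of them.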